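Fluoro for hydrogen on the anilide ring of the dithiocarbamate series

The source may report more compounds than this note shows. Statements on the series, on what has been measured and on what is new or still open speak of the compounds shown alone.

Measured so far in a functional assay on MGC-803 cells (Homo sapiens) for cytotoxicity, read by MTT assay, with a stated time of 72 h; a lower number here means a stronger inhibitor, a higher number a weaker inhibitor:
compound 1 `O=C(CSC(=S)N[C@H]1CCOC1=O)Nc1ccc(Cl)cc1` gives 76900 nM
compound 2 `O=C(CSC(=S)N[C@H]1CCOC1=O)Nc1ccccc1` gives 39700 nM

Going by the values given here, compound 2 stands alongside compound 1 as one of only two numbers, and the two lie within the scatter of each other: the step of a 1.9-fold lower number from compound 1 to compound 2 (0.29 log units; within the scatter) is the whole of what the series shows so far.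

Compound 3 `O=C(CSC(=S)N[C@H]1CCOC1=O)Nc1ccc(F)cc1` is not yet measured. It differs from compound 2 by fluoro in place of hydrogen on an aromatic carbon, the same position at which compound 1 carries chloro. Among the compounds with values here, the one step that bears on it, a 1.9-fold lower number from compound 1 to compound 2 (0.29 log units; within the scatter), was within the scatter, so a halogen at this position has not moved the number in any direction that can be trusted. A step of similar size, or none beyond the scatter, is expected for compound 3 in this assay, and the estimated step of a 1.3-fold higher number from compound 2 to compound 3 (0.10 log units; within the scatter) reflects this. Compound 3 is therefore expected at about 50000 nM, within a range of 25000 nM to 100000 nM.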

Compound 3, half-maximal inhibitory concentration: 37600 nM
Estimate against measurement, compound 3: 1.3-fold (0.12 log units) above, and the stated range covers the measured number.
By their numbers in this assay, from the lowest: compounds 3, 2 and 1 (each within the scatter of the next, the first and the last beyond it).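

In this assay, the change from phenyl to 4-fluorophenyl gives a 1.1-fold lower number from compound 2 to compound 3 (0.02 log units; within the scatter), so fluoro at this position is not told apart from hydrogen, and neither halogen yet separates from hydrogen. Going by these compounds alone, the two halogens do separate, though only modestly: a 2.0-fold lower number from compound 1 to compound 3 (0.31 log units; beyond the scatter) is the one step at this position that lies beyond the scatter, while compound 2 stays within the scatter of both halogen compounds. Nothing available explains the gap between fluoro and chloro here.

Going by these compounds, whether an amine, a carboxylic acid or a methoxy group at this position would move the number beyond the scatter from compound 2 remains open. Also open, on these data alone, is whether the step between chloro and fluoro would persist with another part of the shared core altered.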